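The source may hold more compounds than are shown below. What is called first, only, known or untested is meant among the compounds shown, and "the series" means these compounds.

Three compounds built on one shared core have been examined in an ADME assay on HCT-116 cells (Homo sapiens) for cytotoxicity, read by CellTiter-Glo, with a stated time of 72 h; on this read-out lower numbers stand for stronger inhibition and higher numbers for weaker inhibition. Compound 1 `CC1CCN(C2CCN(S(=O)(=O)c3cccc(-c4ccccc4F)c3)CC2)CC1` gives > 5000 nM in this assay, which is a limit of the assay and not a number. Compound 2 `Cc1nc(Cl)sc1S(=O)(=O)N1CCC(N2CCC(C)CC2)CC1` gives > 10000 nM, again a limit. Compound 3 `CC1CCN(C2CCN(S(=O)(=O)c3ccc(Cl)c(Cl)c3)CC2)CC1` gives > 5000 nM, also a limit. Compound 3 thus stands with the majority of what has been seen so far, at the limit of > 5000 nM in this assay, at which 2 of the 3 values shown sit, while the remaining value sits at the limit of > 10000 nM in this assay, at which 1 of the 3 values shown sits. Within the data shown here, the single step between measured compounds that differ in one place, a step that the two limits leave unreadable from compound 2 to compound 3, therefore yields no readable size.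

The next compound, compound 4 `CC1CCN(C2CCN(S(=O)(=O)c3cccc(N)c3)CC2)CC1`, differs from compound 3 as follows: 3-aminophenyl in place of 3,4-dichlorophenyl on a sulfonyl sulfur. Among the measured compounds shown here, no measured step bears on this change in a readable way, and every value so far is a limit, so the evidence leans toward compound 4 also failing to reach a number in this assay. The step that the limit leaves unreadable from compound 3 to compound 4 is accordingly expected to show no change beyond the scatter. Compound 4 is estimated to give about 10000 nM in this assay, within a range from 4000 nM to 30000 nM, most likely reported as a limit.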

Compound 4, half-maximal inhibitory concentration: > 5000 nM
Compound 4: no number, only a limit; the forecaster's own chance of this, stated with the estimate: 85%; the middle value is on the limit's open side.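

In this assay compound 4 gives > 5000 nM, which is a limit and not a number. Among these compounds, compound 1, compound 2 and compound 3 also give only limits, so no step to compound 4 can be read. The compounds shown leave open what number any of them would give in this assay, and whether changing the group on the sulfonyl sulfur shifts it.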